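This account rests on a few compounds, and the source may have more. Where it says the series, first, only, none or still open, it means among the compounds named here.

- compound 1 `CCCCc1cc2c(=O)c(CC)c(C)[nH]c2cc1OCCOc1ccccc1`: 1000 nM
- compound 2 `CCCCc1cc2c(=O)c(-c3ccc(Cl)cc3C)c(C)[nH]c2cc1OCCOc1ccccc1`: > 21000 nM

In an ADME assay on J774 cells (Mus musculus) for antiproliferative activity, with a stated time of 72 h (on this read-out higher numbers stand for an effect only at larger amounts of compound and lower numbers for an effect already at smaller amounts), compound 1 gives 1000 nM. Compound 2 gives > 21000 nM, which is a limit of the assay and not a number. Going by the values given here, only one measured step bears on what follows: an at least 21-fold higher number from compound 1 to compound 2 (1.32 log units; beyond the scatter). This large step, beyond the scatter, came when 4-chloro-2-methylphenyl replaced ethyl on an aromatic carbon.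

Compound 3 `CCCCc1cc2c(=O)c(-c3c(C)noc3C)c(C)[nH]c2cc1OCCOc1ccccc1` has not yet been measured. It carries 3,5-dimethyl-1,2-oxazol-4-yl in place of 4-chloro-2-methylphenyl at that same place: 3,5-dimethyl-1,2-oxazol-4-yl in place of 4-chloro-2-methylphenyl on an aromatic carbon. The new group is still an aromatic ring, not ethyl, so compound 3 is expected to stay nearer compound 2 than compound 1 in this assay. No step beyond the scatter is expected, though a limit cannot fix its size. The expected change is an at least 1.5-fold lower number from compound 2 to compound 3 (0.17 log units; that floor lies within the scatter). Compound 3 is estimated at 14000 nM, within a range of 4000 nM to 30000 nM.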

Compound 3, half-maximal effective concentration: 22000 nM
Compound 3: middle estimate off by 1.6-fold (0.20 log units), on the low side; the range from low to high includes it.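

With 3,5-dimethyl-1,2-oxazol-4-yl on this aromatic carbon, this assay shows a 22-fold higher number from compound 1 to compound 3 (1.34 log units; beyond the scatter), so a five-membered aromatic ring with 2 hetero atoms also stands far from ethyl, as the six-membered carbon ring of compound 2 did. The hetero atoms and hydrogen-bond acceptors that enter do not bring the number back near the 1000 nM of compound 1. The step between compound 2 and compound 3 cannot be read, because the value of compound 2 is a limit and not a number: the limit of > 21000 nM in this assay, at which 1 of the 3 values shown sits.

Still open, on these data alone, is whether the high numbers go with an aromatic ring as such or simply with a group larger than ethyl. A methyl group, a propyl chain or a cyclopropyl ring at this place would help to separate these two readings.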